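Working notes on a four-compound cytotoxicity series

This account rests on a few compounds, and the source may have more. Where it says the series, first, only, none or still open, it means among the compounds named here.

Measured so far:
Compound 1 `COc1ccc(CNc2nc([SeH])nc3ccccc23)cc1`: in a functional assay on HTB-54 cells (Homo sapiens) for cytotoxicity, read by MTT assay, with a stated time of 72 h (on this read-out lower numbers stand for stronger inhibition of growth and higher numbers for weaker inhibition of growth), compound 1 gives 60900 nM.
Compound 2 `CSc1ccc(CNc2nc([SeH])nc3ccccc23)cc1`: in this assay compound 2 gives > 100000 nM, which is a limit of the assay and not a number.
Compound 3 `COc1ccc(CNc2nc(SC)nc3ccccc23)cc1`: in this assay compound 3 gives > 100000 nM, again a limit of the assay.

From compound 1 to compound 2 the change is methylsulfanyl in place of methoxy on an aromatic carbon; the step is an at least 1.6-fold higher number from compound 1 to compound 2 (0.21 log units; that floor lies within the scatter). The cores of compound 1 and compound 3 differ by a group of 2 heavy atoms (1 carbon, 1 sulfur; no ring) in place of one selenium atom, on an aromatic carbon; that step is an at least 1.6-fold higher number from compound 1 to compound 3 (0.21 log units; that floor lies within the scatter). Both steps are open-ended because of the limit of > 100000 nM in this assay, at which 2 of the 3 values shown sit.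

Compound 4 `CSc1ccc(CNc2nc(SC)nc3ccccc23)cc1` is not yet measured. It arises from compound 3 by methylsulfanyl in place of methoxy on an aromatic carbon, the same change as between compound 1 and compound 2, on the same place. Compound 3 already reports only the limit > 100000 nM. The same change gave an at least 1.6-fold higher number from compound 1 to compound 2 (0.21 log units; that floor lies within the scatter), so compound 4 is expected to remain at or past the limit. Compound 4 is estimated at 150000 nM in this assay, most likely between 100000 nM and 300000 nM. The expected step is accordingly a step that the limit leaves unreadable from compound 3 to compound 4.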

Compound 4, concentration for total growth inhibition: 44500 nM
For compound 4 the middle estimate is 3.4-fold (0.53 log units) above the measured one; the whole stated range lies above it.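

Methylsulfanyl in place of methoxy on an aromatic carbon gives an at least 2.2-fold lower number from compound 3 to compound 4 (0.35 log units; beyond the scatter) in this assay, and the change does not carry over unchanged from the core of compound 1 to the core of compound 3: the same change on two cores in this assay, an at least 1.6-fold higher number (0.21 log units; that floor lies within the scatter) from compound 1 to compound 2 and an at least 2.2-fold lower number (0.35 log units; beyond the scatter) from compound 3 to compound 4, at least 3.6-fold (0.56 log units) apart, beyond the scatter of two such steps

A group of 2 heavy atoms (1 carbon, 1 sulfur; no ring) in place of one selenium atom gives an at least 2.2-fold lower number from compound 2 to compound 4 (0.35 log units; beyond the scatter), so this second change also reads differently depending on the group at the other place: the same change on two cores in this assay, an at least 1.6-fold higher number (0.21 log units; that floor lies within the scatter) from compound 1 to compound 3 and an at least 2.2-fold lower number (0.35 log units; beyond the scatter) from compound 2 to compound 4, at least 3.6-fold (0.56 log units) apart, beyond the scatter of two such steps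

The direction of each change therefore depends on its partner within these four compounds, but the true sizes stay unread and the square of compounds gives no rule for any other core: the limit of > 100000 nM in this assay, at which 2 of the 4 values shown sit.

From the compounds shown here alone, it remains open whether the reversal is specific to methoxy and methylsulfanyl or also appears with other groups at that place, such as a chlorine atom or an amine. Going by these compounds, it is equally open how a longer chain or a carboxylic acid in place of the selenium atom would behave on either side of the pair.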